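The compounds below may be only part of what the source reports. "The series", "measured", "known", "first", "only" and "open" are said of these compounds alone.

Going by the values given here, compound 2 `O=C(O)Cc1sc(Cc2ccccc2)nc1-c1ccc(F)cc1` is the only compound with a number in an in vitro functional assay on HEK285-7 cells for antagonist activity at prostaglandin D2 receptor 2 (Homo sapiens), read by BRET and beta-arrestin recruitment; on this read-out lower numbers stand for smaller maximal responses and higher numbers for larger maximal responses; in this assay compound 2 gives 30%. Compound 1 `O=C(O)Cc1sc(Nc2ccc(Cl)cc2)nc1-c1ccc(F)cc1` reaches only a limit of this assay, > 70%, as noted in the limit of > 70% in this assay, at which 1 of the 2 values shown sits. Among the compounds with values here, the one measured step, a number at least 40 percentage points lower from compound 1 to compound 2 (beyond the scatter), concerns a different position of the shared core. Compound 3 `O=C(O)Cc1sc(Cc2ccccc2Br)nc1-c1ccc(F)cc1` differs from compound 2 by bromo in place of hydrogen on an aromatic carbon. Within the data shown here, no measured step covers this change, so no direction is inferred and a step within the scatter is expected, no change at the digits printed from compound 2 to compound 3 (within the scatter). Compound 3 is therefore estimated at 30% in this assay, within 15% to 50%.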

Compound 3, largest response reached (reported as efficacy), in percent of the reference or control that the assay uses: > 70%
Compound 3: no number, only a limit (the forecaster's own chance of this, stated with the estimate: 10%); at least 40 percentage points between middle value and limit.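

The earlier step replaced a whole group, (4-chlorophenyl)amino; here a single bromo in place of hydrogen on the benzyl group, ortho to a large group, already gives a number at least 40 percentage points higher from compound 2 to compound 3 (beyond the scatter). Compound 3 reaches only a limit in this assay, > 70%, and this is not a number. The step between compound 1 and compound 3 cannot be read: the limit of > 70% in this assay, at which 2 of the 3 values shown sit.

As far as these compounds go, what a chloro, methyl or methoxy group in place of this bromo would give remains open. From the compounds shown here alone, how far compound 3 lies past its limit also remains open.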